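This account rests on a few compounds, and the source may have more. Where it says the series, first, only, none or still open, it means among the compounds named here.

Working notes on compound 1 (`CCN(CC)CCCn1c(N)c(-c2nc3ccccc3[nH]2)c2nc(C#N)c(C#N)nc21`) and its neighbours in a functional assay on HL-60 cells (Homo sapiens) for antiproliferative activity, read by MTT assay, with a stated time of 48 h; a lower number here means a stronger inhibitor, a higher number a weaker inhibitor. Compound 1 gives > 730 nM as a limit and not a number. Compound 2 (`N#Cc1nc2c(-c3nc4ccccc4[nH]3)c(N)n(CCCO)c2nc1C#N`) gives > 50000 nM and this too is a limit. Going by the values given here, compound 3 (`CCN(CC)CCCCn1c(N)c(-c2nc3ccccc3[nH]2)c2nc(C#N)c(C#N)nc21`) gives 460 nM as the only actual number in the set. The standing of compound 1 is therefore only partly readable.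

Compound 4 (`CCN(CC)CCCn1c(N)c(-c2nc3ccccc3n2C)c2nc(C#N)c(C#N)nc21`) keeps the chain of compound 1 and changes one place: methyl in place of hydrogen on an aromatic nitrogen in short, methyl in place of hydrogen on an aromatic nitrogen.

Three measured steps exist, all of them on the saturated chain: a step that the two limits leave unreadable from compound 1 to compound 2 and an at least 1.5-fold lower number from compound 1 to compound 3 (0.20 log units; that floor lies within the scatter) and also an at least 100-fold lower number from compound 2 to compound 3 (2.03 log units; beyond the scatter) as the large one. None of them touches the aromatic nitrogen, so they give no size and no direction for this change. Among the compounds with values here, the only anchor is compound 1 at > 730 nM which is again a limit.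

No step beyond the scatter is therefore expected in this assay and the uncertainty stays wide. The expected change, as an estimate, is a step that the limit leaves unreadable from compound 1 to compound 4 for now. For compound 4 the estimated value is 1200 nM with an expected range from 350 nM to 6000 nM in this assay.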

Compound 4, half-maximal inhibitory concentration: 2810 nM
For compound 4 the middle estimate is 2.3-fold (0.37 log units) below the measured one; the measured number falls inside the stated range.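

No new step can be read in this assay: compound 1 carries only a limit, so the change to compound 4 has no readable size. The compounds shown leave open both the size and the direction of the effect of methyl in place of hydrogen on an aromatic nitrogen in this assay.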